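Diethylcarbamoyl for chloromethyl on a macrocyclic enone scaffold

A few compounds are considered here, and "the series" means these few. Any claim that something is new, unique, unknown or untested is made for them only; others in the source may bear on it.

The series rests on a shared core common to three measured compounds. Compound 1 `CO[C@]1(C)/C=C/C(=O)/C(CO)=C\C[C@](C)(CCC=C(C)C)/C=C/[C@H]1OC(=O)C=C(C)C` gives 15200 nM in a functional assay on SW480 cells (Homo sapiens) for antiproliferative activity, read by MTT assay, with a stated time of 48 h (on this read-out higher numbers stand for weaker inhibition and lower numbers for stronger inhibition), compound 3 `CC(C)=CCC[C@](C)(/C=C/[C@@H](OC(=O)C=C(C)C)[C@](C)(O)/C=C/C(=O)/C=C/N(C)C)CC=O` gives 10300 nM, and compound 2 `CC(C)=CCC[C@]1(C)/C=C/[C@@H](OC(=O)C=C(C)C)[C@](C)(O)/C=C/C(=O)/C(CCl)=C\C1` gives 390 nM. Compound 2 therefore stands at the lowest number of the three, and its gap to both compound 3 and compound 1 lies beyond the usual scatter, so it is the strongest inhibitor among the measured set.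

Compound 4 `CCN(CC)C(=O)/C1=C/C[C@](C)(CCC=C(C)C)/C=C/[C@@H](OC(=O)C=C(C)C)[C@](C)(O)/C=C/C1=O` has not yet been measured. It differs from compound 2 in a single place: diethylcarbamoyl in place of chloromethyl on a double-bonded ring carbon. Among the compounds with values here, no directly comparable pair of measured compounds shares exactly this substitution, so the size of the step is not known from the data. Both measured compounds that lack the chloromethyl group, compound 1 at 15200 nM and compound 3 at 10300 nM, sit far above compound 2, which suggests that departure from this group tends to weaken inhibition. The account therefore expects a step from compound 2 to compound 4 of a 21-fold higher number from compound 2 to compound 4 (1.31 log units; beyond the scatter) toward weaker inhibition in this assay. The author's estimate for compound 4 in this assay is 8000 nM, with a range from 2000 nM to 30000 nM.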

Compound 4, half-maximal inhibitory concentration: 11700 nM
Estimate against measurement, compound 4: 1.5-fold (0.17 log units) below, within the range that was stated.
By their numbers in this assay, from the lowest: compound 2; then compounds 3, 4 and 1 (each within the scatter of the next).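

In this assay the exchange of chloromethyl for diethylcarbamoyl on the double-bonded ring carbon gives a 30-fold higher number from compound 2 to compound 4 (1.48 log units; beyond the scatter) and so moves the compound toward much weaker inhibition, well beyond the scatter. Within the data shown here, this is the first measured change confined to a single place on the shared core, and it shows that this ring carbon alone can carry a large part of the activity of compound 2, which the earlier compounds could not show since each differed from compound 2 in more than one place. Nothing available on the compounds accounts for the size of this step.

The single step removes chloromethyl and introduces diethylcarbamoyl together, so the compounds shown do not separate what leaving of the one group and entry of the other each contribute. On these data alone, it remains open how the same ring carbon would respond to a bromomethyl group, a smaller dimethylcarbamoyl group or a carboxylic acid on an otherwise unchanged compound 2, and whether any such group would stay close to compound 2 in this assay.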